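The source may report more compounds than this note shows. Statements on the series, on what has been measured and on what is new or still open speak of the compounds shown alone.

Compound 1 `O=C1C=CC2(C=C1)OCC(=O)N2S(=O)(=O)c1ccc(Cl)cc1`: > 10000 nM, a limit
Compound 2 `O=C1C=CC2(C=C1)OCC(=O)N2S(=O)(=O)c1ccc([N+](=O)[O-])cc1`: > 10000 nM, a limit
Compound 3 `O=C1C=CC2(C=C1)OCC(=O)N2S(=O)(=O)c1ccc(OC(F)(F)F)cc1`: > 10000 nM, a limit

These results come from a functional assay on HeLa cells (Homo sapiens) for inhibition, read by sulforhodamine B assay, with a stated time of 74 h; a higher number here means a weaker inhibitor, a lower number a stronger inhibitor. Compound 3 gives > 10000 nM, which is a limit and not a number. Among the compounds with values here, it therefore has no exact place of its own, and the series so far comes down to this: the limit of > 10000 nM in this assay, at which 3 of the 3 values shown sit.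

Compound 4 `O=C1C=CC2(C=C1)OCC(=O)N2S(=O)(=O)c1ccc(C(F)(F)F)cc1` keeps the shared core and differs from compound 3 in one place: trifluoromethyl in place of trifluoromethoxy on an aromatic carbon, para to a large group (trifluoromethyl in place of trifluoromethoxy on an aromatic carbon).

Within the data shown here, three measured steps bear on this change, since each swaps the group at that same place. They are a step that the two limits leave unreadable from compound 1 to compound 2, a step that the two limits leave unreadable from compound 1 to compound 3 and a step that the two limits leave unreadable from compound 2 to compound 3. None of them has a readable size, so they give no direct measure for the new step. Still, all three compounds ended at the same limit, so no step beyond the scatter is expected in this assay, and no direction can be named. The estimated step is a step that the limit leaves unreadable from compound 3 to compound 4. The assay may well report only a limit once more. For compound 4 the estimated value is 12000 nM, with an expected range from 4000 nM to 30000 nM.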

Compound 4, half-maximal inhibitory concentration: 770 nM
Estimate against measurement, compound 4: 16-fold (1.19 log units) above; measured number below the stated range.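

In this assay, the group at this place on the aromatic ring can decide whether a compound gives a readable number at all: trifluoromethyl does, and the change to it appears as an at least 12-fold lower number from compound 3 to compound 4 (1.11 log units; beyond the scatter), as an at least 12-fold lower number from compound 2 to compound 4 (1.11 log units; beyond the scatter) and as an at least 12-fold lower number from compound 1 to compound 4 (1.11 log units; beyond the scatter). The step from trifluoromethoxy is the most telling, since trifluoromethoxy and trifluoromethyl differ only by one oxygen, so the loss of that single atom from the group is enough to bring a large change in this cell assay. Compound 4 is thus the only compound shown with a measured number, while the other three stay at a limit: the limit of > 10000 nM in this assay, at which 3 of the 4 values shown sit.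

The steps among compound 1, compound 2 and compound 3 cannot be read, so the order of chloro, nitro and trifluoromethoxy stays unknown, and nothing shown explains why trifluoromethyl stands apart. Also open, on these data alone, is whether a methyl group, a longer chain such as ethyl, or an amine at this same place would give a readable number as well.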